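This account rests on a few compounds, and the source may have more. Where it says the series, first, only, none or still open, it means among the compounds named here.

Compound 1, `Cn1c(C[C@]2(C)CCCO2)cc(=O)n(C)c1=O`: in a functional assay on MDCK cells (Canis lupus familiaris) for inhibition (a higher number here means that more compound is tolerated, a lower number that less compound is tolerated), compound 1 gives 1380000 nM.
Compound 2, `Cn1c(C[C@]2(c3ccccc3)CCCO2)cc(=O)n(C)c1=O`: in this assay compound 2 gives 547000 nM.
Compound 3, `COc1nc(CC2(c3ccccc3)CCCO2)cc(=O)n1C`: in this assay compound 3 gives 130000 nM.

Of the compounds shown here, three have been measured so far; a fourth, compound 4, `COc1nc(CC2(C)CCCO2)cc(=O)n1C`, has not. Compound 2 and compound 1 share one core and differ in a single place: methyl in place of phenyl on a saturated ring carbon. That change gave a 2.5-fold higher number from compound 2 to compound 1 (0.40 log units; beyond the scatter). Compound 3 is built from the same atoms as compound 2, joined differently; how the two cores differ is not broken down here. Among the three measured numbers compound 3 stands lowest, and its gap to compound 2 and to compound 1 is in each case beyond the scatter.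

Compound 4 is to compound 3 what compound 1 is to compound 2: methyl in place of phenyl on a saturated ring carbon. The place is described in the same words for both pairs, so this is the same change, made on the other core. Among the compounds with values here, only one example of it has been measured, and that on a different core, so the expectation carries a wide range. Because the same change gave a 2.5-fold higher number from compound 2 to compound 1 (0.40 log units; beyond the scatter), a step of similar size is expected here: a 2.5-fold higher number from compound 3 to compound 4 (0.40 log units; beyond the scatter). Compound 4 is therefore estimated at 330000 nM in this assay, most likely between 150000 nM and 750000 nM.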

Compound 4, half-maximal cytotoxic concentration: 1620000 nM
Estimate against measurement, compound 4: 4.9-fold (0.69 log units) below; measured number outside the range, above it.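

In this assay, replacing phenyl with methyl on the saturated ring carbon next to the ring oxygen gave a 12-fold higher number from compound 3 to compound 4 (1.10 log units; beyond the scatter), so cells tolerated more of the compound carrying the methyl, just as they did on the first core. The direction of the change therefore carried over from one core to the other, but its size did not: the same change on two cores in this assay, a 2.5-fold higher number (0.40 log units; beyond the scatter) from compound 2 to compound 1 and a 12-fold higher number (1.10 log units; beyond the scatter) from compound 3 to compound 4, 4.9-fold (0.69 log units) apart, beyond the scatter of two such steps. A single earlier step on a different core gave a fair guide to which way the number would move, but not how far, and two pairs of compounds cannot explain the gap or give a rule for what the same change would do on a third core.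

The compounds shown compare only phenyl and methyl at this ring carbon, so it remains open whether a longer chain, such as propyl, or a group such as an amine or a carboxylic acid would give a number close to that of the methyl compound, close to that of the phenyl compound, or outside both. Going by these compounds, it is also open whether a step of different size on each core would appear with these other groups, or whether the gap seen here belongs to the pair phenyl and methyl alone.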